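Working notes: cycloheptyl in place of 4-pentylphenyl

This account rests on a few compounds, and the source may have more. Where it says the series, first, only, none or still open, it means among the compounds named here.

compound 1 `CCCCCc1ccc(C(=O)O[C@@H]2CCC(NC(=O)[C@H](OC)[C@H](O)[C@@H](O)[C@H](O)/C=C/C(C)(C)C)C(=O)NC2)cc1`: 20 nM
compound 2 `CCCCCCCCCCCCCC(=O)O[C@H]1CCC(NC(=O)[C@H](OC)[C@H](O)[C@@H](O)[C@H](O)/C=C/C(C)(C)C)C(=O)N(C)C1`: 10 nM

Both compounds were measured in an in vivo functional assay on the whole organism (MDA-MB-435 cells, Homo sapiens) for antiproliferative activity; on this read-out lower numbers stand for stronger inhibition and higher numbers for weaker inhibition. In this assay compound 1 gives 20 nM and compound 2 gives 10 nM, so the two values lie within the scatter of each other. Within the data shown here, compound 1 therefore stands level with the only other measured compound, and the pair does not separate them.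

Compound 3 `CO[C@@H](C(=O)NC1CC[C@@H](OC(=O)C2CCCCCC2)CNC1=O)[C@H](O)[C@@H](O)[C@H](O)/C=C/C(C)(C)C` has not yet been measured and departs from compound 1 at one place: cycloheptyl in place of 4-pentylphenyl on a carbonyl carbon. In words, this is cycloheptyl in place of 4-pentylphenyl on a carbonyl carbon. Among the measured compounds shown here, the data hold no measured step for a change of this kind, so the size of the step cannot be read from the series. The starting point is compound 1 at 20 nM. No step beyond the scatter is expected, with a slight lean toward weaker inhibition. The expected change is a 1.5-fold higher number from compound 1 to compound 3 (0.18 log units; within the scatter). For compound 3 the estimate is 30 nM, with an expected range of 8 nM to 120 nM.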

Compound 3, half-maximal inhibitory concentration: 20 nM
Compound 3: the middle estimate sits 1.5-fold (0.18 log units) above what was measured; the measured number falls inside the stated range.
By their numbers in this assay, from the lowest: compounds 2, 1 and 3 (each within the scatter of the next).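

Working notes on the carbonyl position: in this assay, cycloheptyl in place of 4-pentylphenyl on a carbonyl carbon gives no change at the digits printed from compound 1 to compound 3 (within the scatter). Among these compounds, this is the first measured step at this place, and it shows that a seven-membered non-aromatic ring of carbon only, with the smaller heavy-atom count, reads level with a six-membered aromatic ring of carbon only that carries a pentyl chain, so within this pair neither the aromatic ring nor the pentyl chain is needed to keep the number where it stands. Nothing on hand bears on why the two groups read alike.

Among the compounds shown here, the single step leaves open how far this holds, since it does not show whether a much smaller group such as cyclopropyl, or an unsubstituted phenyl, would also read level on the same carbonyl carbon. Equally open, going by these compounds, is whether an amine or a carboxylic acid carried on the cycloheptyl ring would keep the number in this assay or move it beyond the scatter.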